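Swapping a Ring Substituent on a Weak Cell-Growth Inhibitor

The source may hold more compounds than are shown below. What is called first, only, known or untested is meant among the compounds shown, and "the series" means these compounds.

Of the compounds shown here, two from this series have been tested in an ADME assay on MRC5 cells (Homo sapiens) for inhibition, with a stated time of 72 h; a higher number here means that more compound is needed for the effect, a lower number that less compound is needed. Compound 1 `COc1cccc(OC)c1C(=O)Nc1c[nH]nc1C(=O)N[C@H]1CC[C@H](OC)CC1` is the weaker of the pair: in this assay compound 1 gives 31000 nM. Compound 2 `CO[C@H]1CC[C@H](NC(=O)c2n[nH]cc2NC(=O)c2ccc(OC(F)F)cc2)CC1` sits well clear of it, as in this assay compound 2 gives 2500 nM, a gap that lies beyond the usual scatter of repeated runs. Compound 2 differs from compound 1 in more than one place, so those two numbers by themselves do not single out which change matters.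

Compound 3 `COc1cccc(OC)c1C(=O)Nc1c[nH]nc1C(=O)NCC1CCCCC1` has not yet been measured. It differs from compound 1 in a single place: cyclohexylmethyl in place of 4-methoxycyclohexyl on an amide-type nitrogen. Among the measured compounds shown here, no measured pair isolates this particular change, so the expectation for compound 3 rests only on where compound 1 stands. With compound 1 already near the weak end of what the assay reports, the expected step from compound 1 to compound 3 is a 1.3-fold higher number from compound 1 to compound 3 (0.11 log units; within the scatter), that is, no clear shift beyond the scatter in either direction. In this assay compound 3 is therefore estimated at 40000 nM, most likely falling between 10000 nM and 120000 nM.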

Compound 3, half-maximal effective concentration: > 50000 nM
Compound 3: a limit, no number; the forecaster's own chance of this, stated with the estimate: 30%; at least 1.2-fold (0.09 log units) between middle value and limit.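

In this assay compound 3 gives > 50000 nM, which is a limit of the assay and not a number. Among the compounds shown here, this is the first change in a single place on the amide-type nitrogen, and putting cyclohexylmethyl in place of 4-methoxycyclohexyl gives an at least 1.6-fold higher number from compound 1 to compound 3 (0.20 log units; that floor lies within the scatter), so the swap brings no move towards a lower number, while the small floor of that step does not by itself establish a real rise. How far the step runs past that floor cannot be read from a limit: the limit of > 50000 nM in this assay, at which 1 of the 3 values shown sits.

The compounds shown do not separate the loss of the methoxy group from the gain of the carbon link to the nitrogen, a question that plain cyclohexyl or 4-methoxycyclohexylmethyl on the same nitrogen would address. They also leave open whether an amine or a carboxylic acid in place of the methoxy group would shift the number, and whether this same swap would act alike on compound 2, whose number is lower.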